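Prostacyclin synthase inhibitors: from compound 3 to compound 4

This account rests on a few compounds, and the source may have more. Where it says the series, first, only, none or still open, it means among the compounds named here.

Measured so far in an assay for inhibition of prostacyclin synthase (Homo sapiens), using microsomes; on this read-out higher numbers stand for weaker inhibition and lower numbers for stronger inhibition:
- compound 1 `N#Cc1ccc(C2OCC(C/C=C\CCC(=O)O)C(c3cccnc3)O2)cc1` gives > 100000 nM, a limit of the assay, not a number.
- compound 2 `N#Cc1ccccc1C1OCC(C/C=C\CCC(=O)O)C(c2cccnc2)O1` gives > 100000 nM, again a limit of the assay.
- compound 3 `CC(C)(Oc1ccccc1F)C1OCC(C/C=C\CCC(=O)O)C(c2cccnc2)O1` gives < 1000 nM, also a limit of the assay.

Compound 3 therefore stands at the limit of < 1000 nM in this assay, at which 1 of the 3 values shown sits, while the other two stand at the limit of > 100000 nM in this assay, at which 2 of the 3 values shown sit. Among the measured compounds shown here, all three values are limits, so no measured step in the set has a readable size: the step that the two limits leave unreadable from compound 1 to compound 2 cannot be read. Compound 4 `CC(C)(Cc1ccc(F)cc1)C1OCC(C/C=C\CCC(=O)O)C(c2cccnc2)O1` is not yet measured. The change from compound 3 to compound 4 is 4-fluorobenzyl in place of 2-fluorophenoxy on a saturated chain carbon bound to two saturated chain carbons and a saturated ring carbon. For the measured compounds named here, no measured step touches this part of the core, so nothing here sets a size for it. For compound 4 the step that the limit leaves unreadable from compound 3 to compound 4 is expected to stay within the scatter. Compound 4 is estimated at 500 nM, in the range 50 nM to 5000 nM.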

Compound 4, half-maximal inhibitory concentration: 2000 nM
Estimate against measurement, compound 4: 4.0-fold (0.60 log units) below, within the range that was stated.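

At the saturated chain carbon bound to two saturated chain carbons and a saturated ring carbon, the series now has its first step with a readable floor: in this assay, 4-fluorobenzyl in place of 2-fluorophenoxy gives an at least 2.0-fold higher number from compound 3 to compound 4 (0.30 log units; that floor lies within the scatter). The value of compound 3 is a limit, so this change is not shown to exceed the scatter. Nothing measured here gives a cause for the step.

As far as these compounds go, the actual value of compound 3 remains open. Also open, from the compounds shown here alone, is whether the change in the linking atom or the change in the fluorine position carries the step, which 4-fluorophenoxy or 2-fluorobenzyl at this place would separate.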